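A few compounds are considered here, and "the series" means these few. Any claim that something is new, unique, unknown or untested is made for them only; others in the source may bear on it.

Measured so far in a functional assay on T47D cells (Homo sapiens) for antiproliferative activity, read by MTT assay, with a stated time of 48 h; on this read-out lower numbers stand for stronger inhibition and higher numbers for weaker inhibition:

compound 1, `COc1ccc(OC)c(/C=N/c2c(C#N)ncn2-c2ccc(F)cc2)c1`, gives 16300 nM
compound 2, `N#Cc1ncn(-c2ccc(F)cc2)c1/N=C/c1ccc([N+](=O)[O-])cc1`, gives 15900 nM
compound 3, `COc1ccc(OC)c(/C=N/c2c(C#N)ncn2Cc2ccc(F)cc2)c1`, gives 22400 nM

Compounds 1 and 3 share the core of compound 1 and differ in one place only: 4-fluorobenzyl in place of 4-fluorophenyl on an aromatic nitrogen. The step this change made in this assay is a 1.4-fold higher number from compound 1 to compound 3 (0.14 log units; within the scatter), so within this pair the exchange of the group on the aromatic nitrogen left the read-out essentially where it was.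

Compound 2 carries a different aryl part on the imine side; how its core differs from that of compound 1 is not broken down here. Its value and that of compound 1 lie within the scatter of each other, and the same holds for compound 2 against compound 3, so no order among the three measured compounds can be stated.

Compound 4, `N#Cc1ncn(Cc2ccc(F)cc2)c1/N=C/c1ccc([N+](=O)[O-])cc1`, is not yet measured. It differs from compound 2 by 4-fluorobenzyl in place of 4-fluorophenyl on an aromatic nitrogen. This is the same change as from compound 1 to compound 3, at the same place on the same ring.

Among the measured compounds shown here, for compound 4 the step expected in this assay is a 1.3-fold higher number from compound 2 to compound 4 (0.12 log units; within the scatter), a step of about the same size as the one measured, because a 1.4-fold higher number from compound 1 to compound 3 (0.14 log units; within the scatter) stayed within the scatter and nothing among the measured compounds points to a different outcome. Compound 4 is therefore estimated at 21000 nM, with the likely range running from 10000 nM to 45000 nM.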

Compound 4, half-maximal inhibitory concentration: 5720 nM
Estimate against measurement, compound 4: 3.7-fold (0.56 log units) above; measured number outside the range, below it.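

In this assay, 4-fluorobenzyl in place of 4-fluorophenyl on an aromatic nitrogen gave a 2.8-fold lower number from compound 2 to compound 4 (0.44 log units; beyond the scatter), so on the core of compound 2 the exchange moved the read-out toward stronger inhibition. The exchange did not carry over unchanged from one core to the other: the same change on two cores in this assay, a 1.4-fold higher number (0.14 log units; within the scatter) from compound 1 to compound 3 and a 2.8-fold lower number (0.44 log units; beyond the scatter) from compound 2 to compound 4, 3.8-fold (0.58 log units) apart, beyond the scatter of two such steps This shows that, in these two pairs, the outcome of the exchange cannot be read across from one core to the other, but with a single pair on each core it does not show which feature of the cores accounts for the gap, nor does it give a rule beyond the four compounds shown.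

As far as these compounds go, only two aryl parts on the imine side appear here, one bearing a nitro group and one bearing methoxy groups, so it remains open whether the lower number seen with 4-fluorobenzyl would recur with any other aryl part, such as one bearing an amine or a carboxylic acid. Also open, from the compounds shown here alone, is how a longer chain between the aromatic nitrogen and the 4-fluorophenyl ring, such as a propyl linker, would behave on either core.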